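The source may hold more compounds than are shown below. What is called first, only, known or untested is meant among the compounds shown, and "the series" means these compounds.

Compound 2 `CCCCCCCCCCCSC(=S)C1=C(Nc2ccc(Cl)cc2)CC(C)(C)CC1=O` was tested in a functional assay on PBMC cells (Homo sapiens) for inhibition, read by thymidine incorporation, with a stated time of 72 h; a higher number here means a weaker inhibitor, a lower number a stronger inhibitor. In this assay compound 2 gives only a limit, > 50 ug/mL, not a number. Compound 1 `CC1(C)CC(=O)C(C(=S)SCc2ccccc2)=C(Nc2ccc(Cl)cc2Cl)C1` likewise gives only a limit in this assay, > 50 ug/mL. Both measured values sit at the limit of > 50 ug/mL in this assay, at which 2 of the 2 values shown sit. Compound 3 `CC1(C)CC(=O)C(C(=S)SCc2ccccc2)=C(Nc2ccc(Cl)cc2)C1` has not yet been measured; it differs from compound 2 by phenyl in place of decyl on a saturated chain carbon bound to a sulfur. With both measured values at the limit of > 50 ug/mL in this assay, at which 2 of the 2 values shown sit, no step beyond the scatter is expected in this assay. The expected step is a step that the limit leaves unreadable from compound 2 to compound 3. Compound 3 is estimated at 70 ug/mL, within 30 ug/mL to 150 ug/mL, most likely reported again only as a limit.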

Compound 3, half-maximal inhibitory concentration: > 50 ug/mL
Compound 3: no number, only a limit (the forecaster's own chance of this, stated with the estimate: 75%); the middle value does not contradict the limit.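

Compound 1, compound 2 and compound 3 all give only limits in this assay, so no step between them can be read: the limit of > 50 ug/mL in this assay, at which 3 of the 3 values shown sit.

From the compounds shown here alone, how strongly any of the three inhibits, and whether swapping decyl for phenyl or chloro for hydrogen changes that, stays open.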